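A few compounds are considered here, and "the series" means these few. Any claim that something is new, unique, unknown or untested is made for them only; others in the source may bear on it.

Measured so far:
- compound 1 `c1ccc(-c2cnco2)c(NCC2=NCCN2)c1`: 17.4 nM
- compound 2 `Cc1noc(-c2ccccc2NCC2=NCCN2)n1`: 661 nM
- compound 3 `Cc1nc(-c2ccccc2NCC2=NCCN2)no1`: 724 nM

In a functional assay for activation of Alpha-1A adrenergic receptor (Homo sapiens), read by calcium flux (on this read-out higher numbers stand for an effect only at larger amounts of compound and lower numbers for an effect already at smaller amounts), compound 3 gives the highest number of the three, but the step that separates it from the nearest measured compound is only a 1.1-fold higher number from compound 2 to compound 3 (0.04 log units; within the scatter), which falls inside the scatter, so the two cannot be told apart. Compound 1 stands far from both: a 42-fold higher number from compound 1 to compound 3 (1.62 log units; beyond the scatter) and a 38-fold higher number from compound 1 to compound 2 (1.58 log units; beyond the scatter).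

Compound 4 `CO/N=C(\C)c1ccccc1NCC1=NCCN1` arises from compound 3 by one change: a group of 5 heavy atoms (3 carbon, 1 nitrogen, 1 oxygen; no ring) in place of a group of 6 heavy atoms (3 carbon, 2 nitrogen, 1 oxygen; one five-membered aromatic ring with 3 hetero atoms), on an aromatic carbon. Going by the values given here, none of the measured steps swaps a ring for a group without a ring; the steps seen only swap one five-membered ring for another, and both such swaps that moved the number at all were large. This change is therefore of unknown size in this assay. The number for compound 4 is expected to lie somewhere between the oxadiazole compounds and compound 1, so a moderately lower number is estimated, a 2.9-fold lower number from compound 3 to compound 4 (0.46 log units; beyond the scatter), with wide uncertainty. Compound 4 is estimated at 250 nM, between 40 nM and 1500 nM.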

Compound 4, half-maximal effective concentration: 20.9 nM
For compound 4 the middle estimate is 12-fold (1.08 log units) above the measured one; measured number below the stated range.
By their numbers in this assay, from the lowest: compounds 1 and 4 (each within the scatter of the next); then compounds 2 and 3 (each within the scatter of the next).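

In this assay, putting the group of 5 heavy atoms with no ring on this aromatic carbon gives a 35-fold lower number from compound 3 to compound 4 (1.54 log units; beyond the scatter) and a 32-fold lower number from compound 2 to compound 4 (1.50 log units; beyond the scatter), both large steps, whereas a 1.2-fold higher number from compound 1 to compound 4 (0.08 log units; within the scatter) stays within the scatter. Among these compounds, then, a low number does not depend on having a five-membered aromatic ring at this place, since a group with no ring cannot be told apart from the 1,3-oxazol-5-yl group, and only the two methyl-1,2,4-oxadiazolyl rings stand apart with higher numbers. Nothing available explains why these groups differ.

The compounds shown leave open how much of this group can be altered while the number stays low. An ethyl in place of the methyl on its oxygen, or a nitrile or an amide in place of the whole group, could each test this.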